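A few compounds are considered here, and "the series" means these few. Any claim that something is new, unique, unknown or untested is made for them only; others in the source may bear on it.

Measured compounds:
compound 1 `CCCc1n[nH]c2c(=O)n(NC(=O)c3ccncc3)c(-c3cccc(OC)c3)nc12` — in a functional assay on SK-MEL-2 cells (Homo sapiens) for cytotoxicity, read by sulforhodamine B assay, with a stated time of 2 days, tested at 100 uM (a higher number here means more inhibition at the concentration tested (going by the name of the read-out), a lower number less inhibition), compound 1 gives 11.4%
compound 2 `O=C(Nn1c(-c2cccc([N+](=O)[O-])c2)nc2c(-c3ccc(Cl)cc3)n[nH]c2c1=O)c1cccnc1` — in this assay compound 2 gives 16.3%

The two values of compound 1 and compound 2 lie within the scatter of each other, so neither can be called stronger or weaker; both show little inhibition at the tested concentration.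

Compound 3 `COc1cccc(-c2nc3c(-c4ccc(Cl)cc4)n[nH]c3c(=O)n2NC(=O)c2ccncc2)c1` is not yet measured. Compared with compound 1 the change is 4-chlorophenyl in place of propyl on an aromatic carbon. Within the data shown here, no pair of measured compounds shows the effect of such a change, so the step is expected to be small, in either direction or none beyond the scatter. Compound 3 is expected to give 15% (range 3% to 30%), a step of a number 3.6 percentage points higher from compound 1 to compound 3 (within the scatter).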

Compound 3, a percentage reported as inhibition, at one concentration (the size of the read-out at that concentration, not a potency): 39.6%
For compound 3 the middle estimate is 24.6 percentage points below the measured one; the measured number lies above the stated range.
By their numbers in this assay, from the lowest: compounds 1 and 2 (each within the scatter of the next); then compound 3.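

In this assay, 4-chlorophenyl in place of propyl on an aromatic carbon of the five-membered aromatic ring gives a number 28.2 percentage points higher from compound 1 to compound 3 (beyond the scatter). Among these compounds, this is the first single-place comparison, and it shows that the group at this position can change the read-out. Nothing measured here explains the step.

From the compounds shown here alone, it remains open whether the ring or its chlorine matters more, and whether size alone could give a similar step. Plain phenyl or a longer chain such as hexyl at this position would help separate these possibilities.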